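Benzothiazole hydrazones: compound 3 to compound 4

This account rests on a few compounds, and the source may have more. Where it says the series, first, only, none or still open, it means among the compounds named here.

Three measured compounds share one core and differ only in the aryl group on the carbon with a double bond to nitrogen. Compound 1 `O=C(N/N=C/c1ccc(O)cc1)c1ccc(-c2nc3ccccc3s2)cc1` gives 11300 nM in an assay on isolated protein for inhibition of Maltase-glucoamylase (Homo sapiens), with a stated time of 15 min; on this read-out higher numbers stand for weaker inhibition and lower numbers for stronger inhibition. Compound 2 `O=C(N/N=C/c1ccc(O)cc1O)c1ccc(-c2nc3ccccc3s2)cc1` gives 5580 nM in this assay, and compound 3 `COc1cccc(/C=N/NC(=O)c2ccc(-c3nc4ccccc4s3)cc2)c1` gives 11100 nM in this assay. Compound 3 stands second highest of the three numbers: its step from compound 1 is a 1.0-fold lower number from compound 1 to compound 3 (0.01 log units; within the scatter), and the step of a 2.0-fold higher number from compound 2 to compound 3 (0.30 log units; within the scatter) is within the scatter. Among the measured compounds shown here, the one change seen beyond the scatter is a 2.0-fold lower number from compound 1 to compound 2 (0.31 log units; beyond the scatter), where the entering group brings a hydroxy.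

Compound 4 `COc1ccc(/C=N/NC(=O)c2ccc(-c3nc4ccccc4s3)cc2)c(I)c1O` is not yet measured. The change is 3-hydroxy-2-iodo-4-methoxyphenyl in place of 3-methoxyphenyl on a carbon with a double bond to nitrogen. For the measured compounds named here, the steps that bear on it are a 2.0-fold lower number from compound 1 to compound 2 (0.31 log units; beyond the scatter), which adds a hydroxy donor and lowers the number modestly, and a 2.0-fold higher number from compound 2 to compound 3 (0.30 log units; within the scatter), which removes two hydroxy groups and stays within the scatter. Going by the values given here, no measured step carries an iodine, so that part of the change is uncharted. A modest lowering in this assay is therefore expected, on the scale of the hydroxy step of compound 1 to compound 2, with a fair chance of nothing beyond the scatter. Compound 4 is estimated at 6500 nM, within 2800 nM to 15000 nM, meaning an expected step of a 1.7-fold lower number from compound 3 to compound 4 (0.23 log units; within the scatter).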

Compound 4, half-maximal inhibitory concentration: 44800 nM
Estimate against measurement, compound 4: 6.9-fold (0.84 log units) below; measured number above the stated range.
By their numbers in this assay, from the lowest: compounds 2, 3 and 1 (each within the scatter of the next, the first and the last beyond it); then compound 4.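

In this assay, the position on a carbon with a double bond to nitrogen proves sensitive to the aryl group: compounds 1, 2 and 3 lay close together, while 3-hydroxy-2-iodo-4-methoxyphenyl gives a 4.0-fold higher number from compound 3 to compound 4 (0.61 log units; beyond the scatter), a 4.0-fold higher number from compound 1 to compound 4 (0.60 log units; beyond the scatter) and an 8.0-fold higher number from compound 2 to compound 4 (0.90 log units; beyond the scatter), the only rises beyond the scatter at this position, leaving compound 4 the weakest of the four. A hydroxy on the aryl group therefore does not go with a lower number in every setting: it does in a 2.0-fold lower number from compound 1 to compound 2 (0.31 log units; beyond the scatter), but compound 4 also carries one and stands highest, so the pattern holds for compound 2 and fails for compound 4. No measurement available here bears on why the number rises.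

Open, going by these compounds, is which part of the change goes with the rise, as the iodine, the hydroxy and the altered methoxy placement enter together in compound 4. Also open, on these data alone, is how a bromine in place of the iodine, or an amine or a carboxylic acid on the aryl group, would read in this assay.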